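Antiproliferative activity of two alkynyl uracil pairs

The source may hold more compounds than are shown below. What is called first, only, known or untested is meant among the compounds shown, and "the series" means these compounds.

Measured compounds:
compound 1, `CC(=O)OCC(CCn1cc(C#Cc2cc(F)cc(F)c2)c(=O)n(C(=O)c2ccccc2)c1=O)COC(C)=O`, 64500 nM
compound 2, `CC(=O)OCC(CCn1cc(C#Cc2ccc(Br)cc2)c(=O)n(C(=O)c2ccccc2)c1=O)COC(C)=O`, 47200 nM
compound 3, `O=c1[nH]c(=O)n(CCC(CO)CO)cc1C#Cc1cc(F)cc(F)c1`, 31200 nM

The three measured compounds were tested in a functional assay on HeLa cells (Homo sapiens) for antiproliferative activity, read by MTT assay, with a stated time of 72 h; on this read-out lower numbers stand for stronger inhibition and higher numbers for weaker inhibition. Compound 1 gives 64500 nM, and compound 2, which differs from it by a single change, gives 47200 nM. That change is 4-bromophenyl in place of 3,5-difluorophenyl on a triple-bonded carbon. The step it made is a 1.4-fold lower number from compound 1 to compound 2 (0.14 log units; within the scatter), so the two values cannot be told apart on this read-out.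

Compound 3 carries a different core; the difference between the core of compound 3 and the core of compound 1 is not broken down here. Compound 3 gives 31200 nM, which is the lowest of the three numbers, though its gap to compound 2 lies within the scatter and only its gap to compound 1 lies beyond it.

Compound 4, `O=c1[nH]c(=O)n(CCC(CO)CO)cc1C#Cc1ccc(Br)cc1`, has not been measured in this assay. It relates to compound 3 as compound 2 relates to compound 1: the change is 4-bromophenyl in place of 3,5-difluorophenyl on a triple-bonded carbon, at the same place, so it is the same change. For the measured compounds named here, since the earlier instance gave a 1.4-fold lower number from compound 1 to compound 2 (0.14 log units; within the scatter), a step of similar size is expected here, a 1.4-fold lower number from compound 3 to compound 4 (0.15 log units; within the scatter), resting on the single measured pair. Compound 4 is therefore estimated at 22000 nM, with a range from 9000 nM to 55000 nM expected to cover most repeat measurements.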

Compound 4, half-maximal inhibitory concentration: 67700 nM
Compound 4: middle estimate off by 3.1-fold (0.49 log units), on the low side; the whole stated range lies below it.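

In this assay, the replacement of 3,5-difluorophenyl by 4-bromophenyl on a triple-bonded carbon gave a 2.2-fold higher number from compound 3 to compound 4 (0.34 log units; beyond the scatter), so the core of compound 3 did not repeat the result seen on the core of compound 1. The two results differ, and the change therefore does not carry over as a fixed step between these two cores: the same change on two cores in this assay, a 1.4-fold lower number (0.14 log units; within the scatter) from compound 1 to compound 2 and a 2.2-fold higher number (0.34 log units; beyond the scatter) from compound 3 to compound 4, 3.0-fold (0.47 log units) apart, beyond the scatter of two such steps. For the compounds shown here, this shows that the single pair on the core of compound 1 was not a reliable guide to the step on the core of compound 3, but with only one pair per core it does not show which of the differences between the cores accounts for the gap, or how the change would behave on any further core.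

The compounds shown leave open how other groups on the triple-bonded carbon, such as an unsubstituted phenyl, a methoxyphenyl or a cyanophenyl, would read out on either core, and whether they would follow the bromine compounds or the fluorine compounds. They also leave open how the same change would run on a core that keeps the acetate esters but lacks the benzoyl group, or on one with a longer chain in place of the present one.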